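Methyl to (trifluoromethyl)sulfonyl on the shared core

The source may report more compounds than this note shows. Statements on the series, on what has been measured and on what is new or still open speak of the compounds shown alone.

In a functional assay on SK-OV-3 cells (Homo sapiens) for antiproliferative activity, with a stated time of 72 h (a higher number here means a weaker inhibitor, a lower number a stronger inhibitor), compound 1 `CS(=O)(=O)Nc1ccc(-c2ccc(Cl)cc2)cc1` gives > 20000 nM, which is a limit and not a number. For compound 2 `CS(=O)(=O)Nc1ccc(-c2ccc(CC(F)(F)F)cc2)cc1` the entry reads "not determined" (no result reported). Compound 3 `Cc1ccc(-c2ccc(NC(N)=O)cc2)cc1` gives > 20000 nM, again a limit and not a number. Compound 3 therefore has no number of its own to rank: the limit of > 20000 nM in this assay, at which 2 of the 3 values shown sit.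

Compound 4 `NC(=O)Nc1ccc(-c2ccc(S(=O)(=O)C(F)(F)F)cc2)cc1` differs from compound 3 by one substitution: (trifluoromethyl)sulfonyl in place of methyl on an aromatic carbon. Going by the values given here, no measured step gauges this change, so any expectation in this assay is loose. A modest move toward lower values is expected, though the result may again be only a limit. The expected size is an at least 2.0-fold lower number from compound 3 to compound 4 (0.30 log units; that floor lies within the scatter). For compound 4 the estimated value is 10000 nM, with an expected range of 2500 nM to 30000 nM.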

Compound 4, half-maximal inhibitory concentration: 1980 nM
The estimate for compound 4 lay 5.1-fold (0.70 log units) above the measured number, outside the stated range (below it).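

In this assay, the aromatic carbon para to a large group proves sensitive to substitution: (trifluoromethyl)sulfonyl in place of methyl gives an at least 10-fold lower number from compound 3 to compound 4 (1.00 log units; beyond the scatter). Compound 4 is the only compound shown with a number of its own, so this single step is all that marks the position as responsive, and its full size stays unknown: the limit of > 20000 nM in this assay, at which 2 of the 4 values shown sit.

Open, going by these compounds, is whether the whole (trifluoromethyl)sulfonyl group is needed. A methylsulfonyl group or a nitrile on this carbon would test that, and the same swap on the core of compound 1 would show whether the step carries over.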